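Cytotoxicity notes: one-carbon extension on the bicyclic amine linker

The compounds below may be only part of what the source reports. "The series", "measured", "known", "first", "only" and "open" are said of these compounds alone.

For the measured compounds named here, compound 2 `Cc1c(CNC[C@@H]2CCCN3CCCC[C@H]23)cc(-c2ccccc2)n1Nc1ccnc2cc(Cl)ccc12` gives 1680 nM in an ADME assay on K562 cells (Homo sapiens) for cytotoxicity, read by MTT assay (on this read-out higher numbers stand for weaker inhibition and lower numbers for stronger inhibition), the lowest of the two numbers measured so far, while compound 1 `CCN(CC)Cc1cc(-c2ccccc2)n(Nc2ccnc3cc(Cl)ccc23)c1C` gives 3620 nM. Going by the values given here, the single measured step, a 2.2-fold lower number from compound 1 to compound 2 (0.33 log units; beyond the scatter), concerns a different place in the molecule and therefore bears only loosely on the change to compound 3 `Cc1c(CNCC[C@@H]2CCCN3CCCC[C@H]23)cc(-c2ccccc2)n1Nc1ccnc2cc(Cl)ccc12`: a group of 11 heavy atoms (10 carbon, 1 nitrogen; 2 six-membered non-aromatic rings with 1 hetero atom each) in place of a group of 10 heavy atoms (9 carbon, 1 nitrogen; 2 six-membered non-aromatic rings with 1 hetero atom each), on a saturated chain carbon bound to an amine nitrogen. Among the compounds with values here, no measured step at this place exists, so for compound 3 a step of no size beyond the scatter is expected in this assay, namely a 1.0-fold higher number from compound 2 to compound 3 (0.01 log units; within the scatter). Compound 3 is estimated at 1700 nM, within a range from 800 nM to 3600 nM.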

Compound 3, half-maximal inhibitory concentration: 2610 nM
Estimate against measurement, compound 3: 1.5-fold (0.19 log units) below, within the range that was stated.
By their numbers in this assay, from the lowest: compounds 2, 3 and 1 (each within the scatter of the next, the first and the last beyond it).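

At the saturated chain carbon bound to an amine nitrogen, the group of 11 heavy atoms in place of the group of 10 heavy atoms gives a 1.6-fold higher number from compound 2 to compound 3 (0.19 log units; within the scatter) in this assay. With both six-membered non-aromatic rings and both defined stereocentres kept, compound 2 and compound 3 therefore cannot be told apart at this place. No evidence on the cause of this step is available. Open, on these data alone, is whether a longer chain at this place, or a morpholine in place of the two rings, would separate from compound 2 in this assay.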